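The compounds below may be only part of what the source reports. "The series", "measured", "known", "first", "only" and "open" are said of these compounds alone.

In a functional assay on SNU-475 cells (Homo sapiens) for inhibition, read by sulforhodamine B assay, with a stated time of 72 h (on this read-out higher numbers stand for weaker inhibition and lower numbers for stronger inhibition), compound 2 `CC(c1ccc(-c2ccccc2)c(F)c1)c1nnc2n1N=C(c1ccc(Cl)cc1)CS2` gives 3800 nM, the lower of the two numbers in hand, though compound 1 `CC(c1ccc(-c2ccccc2)c(F)c1)c1nnc2n1N=C(c1ccc(Cl)cc1Cl)CS2` at 4700 nM sits within the scatter of it; the step of a 1.2-fold lower number from compound 1 to compound 2 (0.09 log units; within the scatter) was small. Compound 3 `CC(c1ccc(-c2ccccc2)c(F)c1)c1nnc2n1N=C(c1ccc(Br)cc1)CS2` differs from compound 2 by bromo in place of chloro on an aromatic carbon. Within the data shown here, no measured step exchanges one halogen for another; the only step seen, a 1.2-fold lower number from compound 1 to compound 2 (0.09 log units; within the scatter), stayed within the scatter, so no movement beyond the scatter is expected in this assay from compound 2 to compound 3. Compound 3 is therefore estimated at 3800 nM, within a range from 1500 nM to 9500 nM, an expected step of no change at the digits printed from compound 2 to compound 3 (within the scatter).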

Compound 3, half-maximal inhibitory concentration: 7000 nM
The estimate for compound 3 lay 1.8-fold (0.27 log units) below the measured number, and the stated range covers the measured number.
By their numbers in this assay, from the lowest: compounds 2, 1 and 3 (each within the scatter of the next).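

In this assay, among these compounds, the exchange of 4-chlorophenyl for 4-bromophenyl gives the first direct reading of one halogen for another at this position, and a 1.8-fold higher number from compound 2 to compound 3 (0.27 log units; within the scatter) lies within the scatter. The change from 2,4-dichlorophenyl to 4-bromophenyl on the same carbon, a 1.5-fold higher number from compound 1 to compound 3 (0.17 log units; within the scatter) also within the scatter, shows that these three aryl groups are not separated on this read-out. No evidence bears on these numbers. The compounds shown leave open whether an amine or a carboxylic acid on this ring would move the number beyond the scatter.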